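Chloro for trifluoromethyl on the methoxy parent

This account rests on a few compounds, and the source may have more. Where it says the series, first, only, none or still open, it means among the compounds named here.

Compound 1 `O=C(Nc1cccc(-n2cc(-c3ccncc3)c(-c3cc(O)cc(Cl)c3)n2)c1)Nc1ccc(Cl)c(C(F)(F)F)c1` gives 102% in a functional assay on BT-549 cells (Homo sapiens) for inhibition, read by sulforhodamine B assay, with a stated time of 48 h, tested at 0.01 uM; a lower number here means a stronger effect, a higher number a weaker effect of the compound at the concentration tested. Compound 2 `O=C(Nc1cccc(-n2cc(-c3ccncc3)c(-c3cc(O)cc(Cl)c3)n2)c1)Nc1ccc(Cl)c(Cl)c1` gives 94% in this assay, and compound 3 `COc1cc(Cl)cc(-c2nn(-c3cccc(NC(=O)Nc4ccc(Cl)c(C(F)(F)F)c4)c3)cc2-c2ccncc2)c1` gives 92% in this assay. All three numbers sit close to the untreated control at this concentration. Compound 3 holds the lowest of the three numbers; compound 2 is nearest to it and compound 1 furthest, and both gaps lie within the scatter, so no order among the three can be read from them. The two measured single-point steps are a number 8 percentage points lower from compound 1 to compound 2 (within the scatter) and a number 10 percentage points lower from compound 1 to compound 3 (within the scatter).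

Compound 4 `COc1cc(Cl)cc(-c2nn(-c3cccc(NC(=O)Nc4ccc(Cl)c(Cl)c4)c3)cc2-c2ccncc2)c1` is not yet measured in this assay. It differs from compound 3 in one place: chloro in place of trifluoromethyl on an aromatic carbon. Going by the values given here, the one measured step that bears on this exchange is the same swap on the hydroxy parent, a number 8 percentage points lower from compound 1 to compound 2 (within the scatter), which stayed within the scatter. Nothing in the series suggests the methoxy parent would respond differently, so no step beyond the scatter is expected in this assay, with at most a slight drift downward in the direction seen from compound 1 to compound 2.

Compound 4 is therefore expected to give 88% in this assay, with a range from 76% to 100%. The estimated step is a number 4 percentage points lower from compound 3 to compound 4 (within the scatter), within the scatter.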

Compound 4, a percentage reported as activity, at one concentration (the size of the read-out at that concentration, not a potency): 96%
Compound 4: middle estimate off by 8 percentage points, on the low side; measured number inside the range.
By their numbers in this assay, from the lowest: compounds 3, 2, 4 and 1 (each within the scatter of the next).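

With compound 4, the exchange from 4-chloro-3-(trifluoromethyl)phenyl to 3,4-dichlorophenyl can now be read on a second core in this assay, with a number 4 percentage points higher from compound 3 to compound 4 (within the scatter), and the readings on the two cores cannot be told apart: the same change on two cores in this assay, a number 8 percentage points lower (within the scatter) from compound 1 to compound 2 and a number 4 percentage points higher (within the scatter) from compound 3 to compound 4, 12 percentage points apart, within the scatter of two such steps

The methyl on the oxygen can also be read on a second background, with a number 2 percentage points higher from compound 2 to compound 4 (within the scatter), and again the two readings cannot be told apart: the same change on two cores in this assay, a number 10 percentage points lower (within the scatter) from compound 1 to compound 3 and a number 2 percentage points higher (within the scatter) from compound 2 to compound 4, 12 percentage points apart, within the scatter of two such steps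

Neither exchange therefore gives a readable effect at this concentration on either background, so the earlier single readings now have a counterpart and neither one depends visibly on the other exchange.

Open, from the compounds shown here alone, is whether a more differently built group on the same aromatic carbon, such as a nitrile, an amine or a carboxylic acid, would move the number beyond the scatter. Also open, going by these compounds, is whether these four compounds would separate at a higher concentration or in a full concentration series, since a single point this close to the untreated control cannot rank them.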